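Notes on a pyridine-linked hydroxyphenyl series: compound 4

The source may report more compounds than this note shows. Statements on the series, on what has been measured and on what is new or still open speak of the compounds shown alone.

Measured so far in an ADME assay on HEK293 cells (Homo sapiens) for cytotoxicity, read by CCK-8 assay and cell counting, with a stated time of 2 days; a lower number here means a stronger inhibitor, a higher number a weaker inhibitor:
compound 1 `Oc1ccc(-c2cc(-c3cccc(Cl)c3)nc(-c3ccccn3)c2)cc1` gives 25400 nM
compound 2 `Oc1ccc(-c2cc(-c3ccsc3)nc(-c3cccc(Cl)c3)c2)cc1` gives 2670 nM
compound 3 `Oc1cccc(-c2cc(-c3ccsc3)nc(-c3cccc(Cl)c3)c2)c1` gives 3180 nM

Compound 2 and compound 3 sit together: the step of a 1.2-fold higher number from compound 2 to compound 3 (0.08 log units; within the scatter) is within the scatter, so no order between them can be read. Compound 1 stands apart, with a 9.5-fold lower number from compound 1 to compound 2 (0.98 log units; beyond the scatter) separating it from compound 2.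

The next compound, compound 4 `Oc1ccc(-c2cc(-c3cccc(Cl)c3)nc(-c3ccco3)c2)cc1`, is reached from compound 2 by a single change: furan-2-yl in place of thiophen-3-yl on an aromatic carbon. The place is the same one where the step from compound 1 to compound 2 acted, and that step, thiophen-3-yl in place of pyridin-2-yl, gave a 9.5-fold lower number from compound 1 to compound 2 (0.98 log units; beyond the scatter) in this assay. For the measured compounds named here, the present change swaps one five-membered aromatic ring with one hetero atom for another of the same kind, which is a smaller change than the one from pyridin-2-yl; no measured step covers it directly. The expectation is therefore a step from compound 2 that stays within or near the scatter, a 1.3-fold higher number from compound 2 to compound 4 (0.12 log units; within the scatter), with no clear direction. Compound 4 is estimated at 3500 nM in this assay, within a range from 1200 nM to 10000 nM.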

Compound 4, half-maximal inhibitory concentration: 2880 nM
Compound 4: middle estimate off by 1.2-fold (0.08 log units), on the high side; measured number inside the range.
By their numbers in this assay, from the lowest: compounds 2, 4 and 3 (each within the scatter of the next); then compound 1.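

In this assay, the position next to the ring nitrogen now has a second five-membered aromatic ring with 1 hetero atom, and a 1.1-fold higher number from compound 2 to compound 4 (0.03 log units; within the scatter) leaves furan-2-yl and thiophen-3-yl indistinguishable, so neither sulfur for oxygen nor the different point of attachment produces a readable effect here. Furan-2-yl also stands clear of pyridin-2-yl, with an 8.8-fold lower number from compound 1 to compound 4 (0.95 log units; beyond the scatter), so the separation of compound 1 seen earlier with thiophen-3-yl is not confined to that one ring: across the three groups at this position, both five-membered rings sit together and pyridin-2-yl sits apart, with no listed compound going against this. No measurement available here bears on what lies behind these numbers.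

As far as these compounds go, whether the separation follows ring size or the pyridine nitrogen stays open, and a plain phenyl group at this position would separate the two readings. From the compounds shown here alone, all three groups here are aromatic rings, so it also remains unknown how an amine, a carboxylic acid or a short alkyl chain at the same carbon would read in this assay.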